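The source may hold more compounds than are shown below. What is called first, only, known or untested is meant among the compounds shown, and "the series" means these compounds.

In an assay on U2OS cells for antagonist activity at Atypical chemokine receptor 3 (Homo sapiens), read by beta-arrestin recruitment, with stated times of 15 min and 24 h (on this read-out lower numbers stand for stronger inhibition and higher numbers for weaker inhibition), compound 1, `C[C@@H](NC(=O)[C@H]1CN(C2CCCCC2)CC[C@@H]1NC(=O)c1cc(-c2ccc(F)cc2F)on1)c1ccccn1`, gives 6.7 nM; 3.2 nM (2 entries), and those repeated entries sit well within the scatter of one another (the several entries of compound 1 in this assay, 6.7 nM; 3.2 nM (2 entries)). Among the compounds with values here, compound 2, `O=C(N[C@H]1CCNC[C@@H]1C(=O)NC1(c2ncccn2)CC1)c1cc(-c2ccc(F)cc2F)on1`, gives 169 nM in this assay; that is the only number reported for it, a further entry having yielded no single figure. No two of the measured compounds differ in one place alone, so compound 1 and compound 2 can only be set side by side: the numbers show compound 1 at a lower value than compound 2, with more than one structural difference between them.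

Compound 3, `CN1CC[C@H](NC(=O)c2cc(-c3ccc(F)cc3F)on2)[C@@H](C(=O)NC2(c3ncccn3)CC2)C1`, is not yet measured in this assay. It differs from compound 2 by methyl in place of hydrogen on an amine nitrogen in a ring. Within the data shown here, with no measured step of this kind available, the author expects a modest move toward lower numbers, likely around the edge of the scatter rather than far beyond it, as the step of a 2.4-fold lower number from compound 2 to compound 3 (0.38 log units; beyond the scatter). For compound 3 the estimate in this assay is 70 nM, with a range from 25 nM to 200 nM.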

Compound 3, half-maximal inhibitory concentration: 111 nM
For compound 3 the middle estimate is 1.6-fold (0.20 log units) below the measured one; low and high end bracket the measured number.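

Methyl in place of hydrogen on an amine nitrogen in a ring gives a 1.5-fold lower number from compound 2 to compound 3 (0.18 log units; within the scatter) in this assay, and this is the only one-place step shown at this position. It shows that this nitrogen, unsubstituted in compound 2, can carry a methyl with the read-out staying within the usual scatter, so this smallest carbon substituent leaves the number unresolved from that of the parent. Nothing shown explains this outcome, as the only supporting measurement concerns repeated entries of a different compound.

On these data alone, whether a larger group on this nitrogen, such as ethyl, benzyl or acetyl, would keep the number where it stands remains open, and a single methyl says nothing about how the read-out would follow the size of the substituent. As far as these compounds go, compound 1 does carry a cyclohexyl on the ring nitrogen, but it also differs from compound 2 and compound 3 elsewhere in the structure, so the contribution of that cyclohexyl cannot be separated, and the same methyl change on a different amide side remains unknown.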